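A few compounds are considered here, and "the series" means these few. Any claim that something is new, unique, unknown or untested is made for them only; others in the source may bear on it.

Compound 2 `COc1cc(C/N=C(\S)NCC(COC(=O)C(C)(C)C)Cc2ccc(C)c(C)c2)ccc1NS(C)(=O)=O` gives 22 nM in a functional assay on CHO cells with transient receptor potential cation channel subfamily V member 1 (Rattus norvegicus) as the target (a lower number here means that less compound is needed, a higher number that more compound is needed for the effect), the lowest of the two numbers at hand. Compound 1 `Cc1ccc(CC(CN/C(S)=N/Cc2cccc(NS(C)(=O)=O)c2)COC(=O)C(C)(C)C)cc1C` gives 990 nM in this assay, a gap beyond the scatter. Compound 3 `COc1cc(C/N=C(\S)NCC(COC(=O)C(C)(C)C)Cc2ccc(C(C)(C)C)cc2)ccc1NS(C)(=O)=O` is not yet measured; it differs from compound 2 by 4-(tert-butyl)phenyl in place of 3,4-dimethylphenyl on a saturated chain carbon, three bonds along the chain from an amine nitrogen and an oxygen next to a carbonyl group. Among the compounds with values here, no measured pair isolates this change, so the size of the step is open. The expectation is that the step from compound 2 to compound 3 in this assay stays within the scatter, a 1.5-fold lower number from compound 2 to compound 3 (0.17 log units; within the scatter). Compound 3 is thus estimated at 15 nM in this assay, within 4 nM to 60 nM.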

Compound 3, half-maximal effective concentration: 40 nM
For compound 3 the middle estimate is 2.7-fold (0.43 log units) below the measured one, within the range that was stated.
By their numbers in this assay, from the lowest: compounds 2 and 3 (each within the scatter of the next); then compound 1.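

At this place, on a saturated chain carbon, 4-(tert-butyl)phenyl can replace 3,4-dimethylphenyl with a 1.8-fold higher number from compound 2 to compound 3 (0.26 log units; within the scatter) in this assay and so the two groups are not told apart here. Within the data shown here, the earlier compounds both carried 3,4-dimethylphenyl, so this is the first reading of any change at this place. No data at hand explain this result.

On these data alone, whether an unsubstituted phenyl, a pyridine or a cyclohexyl ring reads alike at this place remains open. Also open, as far as these compounds go, is whether the same change reads alike on the core of compound 1.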